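A few compounds are considered here, and "the series" means these few. Any claim that something is new, unique, unknown or untested is made for them only; others in the source may bear on it.

Of the compounds shown here, two have been measured. In a functional assay on KG-1a cells (Homo sapiens) for inhibition, read by MTT assay, with a stated time of 72 h (on this read-out higher numbers stand for weaker inhibition and lower numbers for stronger inhibition), compound 1 `Cc1ccc(-c2nnc(-c3ccc(CN4CCN(C)CC4)cc3)o2)cc1Nc1nccc(-c2cccnc2)n1` gives 1780 nM. In this assay compound 2 `Cc1ccc(-c2nnc(-c3ccc(CN4CCN(CCN=C=S)CC4)c(C(F)(F)F)c3)o2)cc1Nc1nccc(-c2cccnc2)n1` gives 940 nM; compound 2 stands at the low end of the two numbers, but the gap to compound 1 is within the usual scatter, so no order between them can be read. Compound 3 `Cc1ccc(-c2nnc(-c3ccc(CN4CCN(CCN=C=S)CC4)cc3)o2)cc1Nc1nccc(-c2cccnc2)n1` has not been measured; it differs from compound 2 by hydrogen in place of trifluoromethyl on an aromatic carbon. Within the data shown here, no step between measured compounds covers this change, and none beyond the scatter is expected in this assay in either direction. Compound 3 is expected to give 1200 nM (range 500 nM to 3000 nM), an expected step of a 1.3-fold higher number from compound 2 to compound 3 (0.11 log units; within the scatter).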

Compound 3, half-maximal inhibitory concentration: 370 nM
For compound 3 the middle estimate is 3.2-fold (0.51 log units) above the measured one; measured number outside the range, below it.
By their numbers in this assay, from the lowest: compound 3; then compounds 2 and 1 (each within the scatter of the next).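

In this assay this aromatic carbon gives its first step beyond the scatter: hydrogen in place of trifluoromethyl lowers the number (a 2.5-fold lower number from compound 2 to compound 3 (0.40 log units; beyond the scatter)). With hydrogen on that carbon, the group of 4 heavy atoms on the saturated chain carbon bound to the amine nitrogen in a ring also separates from compound 1 (a 4.8-fold lower number from compound 1 to compound 3 (0.68 log units; beyond the scatter)), which compound 2 could not show. Nothing available bears on the cause of either step.

As far as these compounds go, whether fluorine, chlorine or methyl on this aromatic carbon stays closer to hydrogen or to trifluoromethyl remains open. Also open, from the compounds shown here alone, is whether a plain ethyl or aminoethyl chain on the ring nitrogen would keep the lower number.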